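The compounds below may be only part of what the source reports. "The series", "measured", "known", "first", "only" and "open" are said of these compounds alone.

Working notes on the series. Three compounds have numbers in an ADME assay for permeability, using PAMPA, with a stated time of 30 min, at pH 7.4; a higher number here means that the compound crosses the layer faster, a lower number that the compound crosses the layer more slowly. Compound 1 `COc1cccc(CNCCCNc2ccnc3cc(-c4ccc(C(C)(C)C)cc4)ccc23)c1O` gives 237 10^-6 cm/s. Compound 2 `COc1cccc(CNCCCNc2ccnc3cc(CCC(C)C)ccc23)c1O` gives 23 10^-6 cm/s. Compound 3 `COc1cccc(CNCCCNc2ccnc3cc(Oc4cccc(N(C)C)c4)ccc23)c1O` gives 317 10^-6 cm/s, the highest of the three numbers; compound 1 sits within the scatter of it, compound 2 well away from it. The two steps that end at compound 3 differ sharply in size: a 1.3-fold higher number from compound 1 to compound 3 (0.13 log units; within the scatter), whereas a 14-fold higher number from compound 2 to compound 3 (1.14 log units; beyond the scatter). Between compound 1 and compound 2 the step is a 10-fold lower number from compound 1 to compound 2 (1.01 log units; beyond the scatter).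

Compound 4 `COc1cccc(CNCCCNc2ccnc3cc(-c4ccc(C(F)(F)F)cc4)ccc23)c1O` is the next member, not yet measured in this assay. It differs from compound 3 at one place: 4-(trifluoromethyl)phenyl in place of 3-(dimethylamino)phenoxy on an aromatic carbon. The change puts compound 4 close to compound 1 in build, a para-substituted phenyl on the same carbon of the shared core, and the step from compound 1 to compound 3 stayed within the scatter. The large steps in this assay both involve compound 2, which has no part in this change. Compound 4 is therefore expected to land near compound 1 and compound 3, with no step beyond the scatter; the expected step is a 1.4-fold lower number from compound 3 to compound 4 (0.14 log units; within the scatter). The estimate for compound 4 in this assay is 230 10^-6 cm/s, with a range from 120 10^-6 cm/s to 420 10^-6 cm/s.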

Compound 4, apparent permeability: 237 10^-6 cm/s
Beside the measured number, compound 4's estimate is 1.0-fold (0.01 log units) below it; measured number inside the range.
By their numbers in this assay, from the lowest: compound 2; then compounds 1, 4 and 3 (each within the scatter of the next).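

In this assay, going by these compounds alone, the swap of trifluoromethyl for tert-butyl on the terminal phenyl gives no change at the digits printed from compound 1 to compound 4 (within the scatter), the first direct reading of that group on the phenyl ring, and it shows that these two groups are not told apart here. The step of a 1.3-fold lower number from compound 3 to compound 4 (0.13 log units; within the scatter) shows the same for two aromatic groups of 10 heavy atoms each, although the entering group has no hydrogen-bond acceptors where the leaving one has 2, while a 10-fold higher number from compound 2 to compound 4 (1.01 log units; beyond the scatter) repeats with a second aryl group the large gap first seen for isopentyl, so that among the listed compounds only compound 2 stands apart from the others. No measurement in hand explains either the flat steps or the large one.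

With isopentyl the only group here that has no aromatic ring, the compounds shown cannot separate the presence of a ring from the size or shape of the group, which a cyclohexyl group or a longer alkyl chain on the same aromatic carbon would address. Going by these compounds, it also remains open whether the flat response among the aromatic groups would hold for a phenyl ring carrying a carboxylic acid or a primary amine.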